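A few compounds are considered here, and "the series" means these few. Any claim that something is new, unique, unknown or untested is made for them only; others in the source may bear on it.

Measured in an ADME assay on K562 cells (Homo sapiens) for cytotoxicity, with a stated time of 72 h; a higher number here means a weaker inhibitor, a lower number a stronger inhibitor:
- Compound 1 `Oc1ccc(CNc2ncnc3c2ncn3C2CCCCO2)cc1`: > 100000 nM
- Compound 2 `COc1ccccc1CNc1ncnc2c1ncn2C1CCCCO1`: 97000 nM
- Compound 3 `COc1cccc(CNc2ncnc3c2ncn3C2CCCCO2)c1`: 61000 nM

Compound 1 has a limit of the assay, not a true number. That leaves compound 2 with only compound 3 for a numerical comparison, and a 1.6-fold lower number from compound 2 to compound 3 (0.20 log units; within the scatter) shows that the two cannot be told apart.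

Compound 4 `COc1ccc(CNc2ncnc3c2ncn3C2CCCCO2)c(OC)c1` keeps all of compound 2 and gains one group: methoxy in place of hydrogen on an aromatic carbon. The new methoxy sits in place of hydrogen on an aromatic carbon, meta to the existing methoxy group and para to a large group.

For the measured compounds named here, no measured pair adds a second methoxy, so the evidence is indirect. Moving the methoxy group gave a 1.6-fold lower number from compound 2 to compound 3 (0.20 log units; within the scatter), and replacing 4-hydroxyphenyl gave an at least 1.0-fold lower number from compound 1 to compound 2 (0.01 log units; that floor lies within the scatter) and an at least 1.6-fold lower number from compound 1 to compound 3 (0.21 log units; that floor lies within the scatter). None of these steps clearly exceeds the scatter, so no clear change is expected in this assay. The estimated step is a 1.4-fold lower number from compound 2 to compound 4 (0.14 log units; within the scatter), with any shift expected to stay within the scatter. For compound 4 the expected value is 70000 nM, with an estimated range of 30000 nM to 100000 nM.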

Compound 4, half-maximal inhibitory concentration: > 25000 nM
Compound 4 gave a limit, no number; the forecaster's own chance of this, stated with the estimate: 30%; the middle value lies beyond the limit too.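

In this assay compound 4 gives > 25000 nM, which is a limit of the assay and not a number. The step from compound 2 to compound 4 cannot be read. The compounds shown leave open whether adding this second methoxy changes the value at all.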